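The source may hold more compounds than are shown below. What is called first, only, known or untested is meant among the compounds shown, and "the series" means these compounds.

Notes on the series. Compound 2 `CC(C)(C)Cn1cc2c(Cl)nc(NC(=O)c3ccccc3)nc2n1` gives 30300 nM in an assay on CHO cells for displacement of a labelled ligand from adenosine receptor A3 (Homo sapiens), read by scintillation counting, with a stated time of 3 h; a higher number here means a weaker inhibitor, a lower number a stronger inhibitor. Compound 1 `Cc1ccc(C(=O)Nc2nc(Cl)c3cn(CC(C)(C)C)nc3n2)cc1` gives 5000 nM in this assay; it differs from compound 2 by methyl in place of hydrogen on an aromatic carbon, and the step is a 6.1-fold lower number from compound 2 to compound 1 (0.78 log units; beyond the scatter). Compound 3 `CC(C)n1cc2c(Cl)nc(NC(=O)c3ccccc3)nc2n1` gives 12800 nM in this assay; its core differs from that of compound 2 by isopropyl in place of neopentyl on an aromatic nitrogen, with a step of a 2.4-fold lower number from compound 2 to compound 3 (0.37 log units; beyond the scatter). Compound 4 `Cc1ccc(C(=O)Nc2nc(Cl)c3cn(C(C)C)nc3n2)cc1` is not yet measured. It differs from compound 3 by methyl in place of hydrogen on an aromatic carbon, the same change as that made from compound 2 to compound 1, at the same place. Resting on the modest gain seen in a 6.1-fold lower number from compound 2 to compound 1 (0.78 log units; beyond the scatter), a step of similar size is expected for compound 4, a 5.1-fold lower number from compound 3 to compound 4 (0.71 log units; beyond the scatter), with some allowance for the different core. Compound 4 is estimated at 2500 nM, expected to fall between 1000 nM and 7000 nM.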

Compound 4, inhibition constant: > 100000 nM
Compound 4: a limit, no number; the forecaster's own chance of this, stated with the estimate: 3%; middle value at least 40-fold (1.60 log units) away from the limit.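

In this assay compound 4 gives > 100000 nM, which is a limit of the assay and not a number, so the steps into it give only a bound. Phenyl to 4-methylphenyl does not carry over from the neopentyl core to the isopropyl core, where the change gives an at least 7.8-fold higher number from compound 3 to compound 4 (0.89 log units; beyond the scatter): the same change on two cores in this assay, a 6.1-fold lower number (0.78 log units; beyond the scatter) from compound 2 to compound 1 and an at least 7.8-fold higher number (0.89 log units; beyond the scatter) from compound 3 to compound 4, at least 47-fold (1.67 log units) apart, beyond the scatter of two such steps Isopropyl in place of neopentyl likewise gives an at least 20-fold higher number from compound 1 to compound 4 (1.30 log units; beyond the scatter), so the two changes do not simply add, although two cores and a limit show neither the full size of this reversal nor any general rule: the same change on two cores in this assay, a 2.4-fold lower number (0.37 log units; beyond the scatter) from compound 2 to compound 3 and an at least 20-fold higher number (1.30 log units; beyond the scatter) from compound 1 to compound 4, at least 47-fold (1.67 log units) apart, beyond the scatter of two such steps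

Going by these compounds, it remains open whether methoxy or chloro in place of the methyl would follow compound 1 or compound 4. On these data alone, the behaviour of an ethyl or a longer chain on the aromatic nitrogen also remains open.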